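A few compounds are considered here, and "the series" means these few. Any claim that something is new, unique, unknown or untested is made for them only; others in the source may bear on it.

In a functional assay on MDA-MB-453 cells (Homo sapiens) for cytotoxicity, read by MTT assay, with a stated time of 48 h (a lower number here means a stronger inhibitor, a higher number a weaker inhibitor), compound 2 (`N#Cc1ccc(OCc2nnc(-c3ccccc3)o2)cc1F`) gives > 50000 nM, which is a limit of the assay and not a number. Compound 3 (`COc1ccc(-c2nnc(COc3ccc(C#N)c(F)c3)o2)cc1`) has methoxy in place of hydrogen on an aromatic carbon, para to a large group, turning phenyl to 4-methoxyphenyl: methoxy in place of hydrogen on an aromatic carbon. Compound 1 (`COc1ccc(-c2nnc(COc3ccc(C#N)cc3OC)o2)cc1`) also carries 4-methoxyphenyl, though it differs elsewhere too, and gives 13000 nM, so a moderate move toward stronger inhibition seems likely. The expected change is an at least 2.2-fold lower number from compound 2 to compound 3 (0.35 log units; beyond the scatter). For compound 3 the estimated value is 22000 nM, with an expected range of 8000 nM to 50000 nM.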

Compound 3, half-maximal inhibitory concentration: 45500 nM
Compound 3: the middle estimate sits 2.1-fold (0.32 log units) below what was measured; measured number inside the range.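

With methoxy on the phenyl ring, para to a large group, compound 3 gives a real number where compound 2 gave only a limit, so this change can now be sized, though only from one side. The step reads an at least 1.0-fold lower number from compound 2 to compound 3 (0.04 log units; that floor lies within the scatter) and is a floor, not a full size. Both a real gain and no gain remain possible, because one end of the step is a limit: the limit of > 50000 nM in this assay, at which 1 of the 3 values shown sits.

Going by these compounds, the true size of this step remains open. So does what an amine or a carboxylic acid at this same place would give.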